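Chloro on the methoxyphenyl amine of compound 2

The compounds below may be only part of what the source reports. "The series", "measured", "known", "first", "only" and "open" are said of these compounds alone.

Compound 1 `CCS(=O)(=O)Nc1cc(-c2ccc3ncnc(Nc4cccc(F)c4)c3c2)cnc1OC` and compound 2 `CCS(=O)(=O)Nc1cc(-c2ccc3ncnc(Nc4ccc(OC)cc4)c3c2)cnc1OC` share one core and differ only in the aryl group on the amine nitrogen. In a functional assay on SNU-638 cells (Homo sapiens) for cytotoxicity, read by sulforhodamine B assay, with a stated time of 72 h (a higher number here means a weaker inhibitor, a lower number a stronger inhibitor), compound 1 gives 2760 nM and compound 2 gives 3970 nM. Going by the values given here, these two values lie within the scatter of one another, so compound 2 is not set apart on the numbers so far; the single step, a 1.4-fold higher number from compound 1 to compound 2 (0.16 log units; within the scatter), is likewise within the scatter. Compound 3 `CCS(=O)(=O)Nc1cc(-c2ccc3ncnc(Nc4ccc(OC)c(Cl)c4)c3c2)cnc1OC` carries chloro in place of hydrogen on an aromatic carbon. No measured step adds a chloro, and the one step shown does not bear on this change, so no shift beyond the scatter in this assay is expected. The expected step is a 1.1-fold lower number from compound 2 to compound 3 (0.05 log units; within the scatter). Compound 3 is estimated at 3500 nM, range 1400 nM to 9000 nM.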

Compound 3, half-maximal inhibitory concentration: 3620 nM
Compound 3: middle estimate off by 1.0-fold (0.01 log units), on the low side, within the range that was stated.
By their numbers in this assay, from the lowest: compounds 1, 3 and 2 (each within the scatter of the next).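

In this assay, chloro in place of hydrogen on the aromatic carbon ortho to a methoxy group gives a 1.1-fold lower number from compound 2 to compound 3 (0.04 log units; within the scatter), so this place accepts the chlorine atom with no shift beyond the scatter. The full aryl exchange, 3-chloro-4-methoxyphenyl in place of 3-fluorophenyl, also stays within the scatter, with a 1.3-fold higher number from compound 1 to compound 3 (0.12 log units; within the scatter). No supporting data bear on this result.

Open, going by these compounds, is whether an amine or a carboxylic acid at this same place would move the number beyond the scatter. Also open, on these data alone, is whether any change away from this aryl group would do so, such as a longer chain on the sulfonyl group.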